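The source may hold more compounds than are shown below. What is called first, only, known or untested is meant among the compounds shown, and "the series" means these compounds.

Three compounds have been measured:

compound 1 `COc1ccc(CNC(=O)c2nc(-c3ccc(F)cc3)n(CC[C@@H](O)C[C@@H](O)CC(=O)O)c2C2CC2)cc1F` gives 0.2 nM in a functional assay on cells (Hepatocyte, Rattus norvegicus) for inhibition, read by scintillation counting, with a stated time of 4 h; a higher number here means a weaker inhibitor, a lower number a stronger inhibitor
compound 2 `COc1ccc(CNC(=O)c2nc(-c3ccc(F)cc3)n(CC[C@@H](O)C[C@@H](O)CC(=O)O)c2C2CC2)cc1` gives 0.2 nM
compound 3 `CC(C)c1c(C(=O)NCc2ccccc2)nc(-c2ccc(F)cc2)n1CC[C@@H](O)C[C@@H](O)CC(=O)O` gives 0.3 nM

Compound 2 stands level with compound 1, the two together at the lowest numbers of the three, and compound 3 sits close by: its gap to compound 2 is within the scatter, so no order among the three can be read from these values. One step has been measured: no change at the digits printed from compound 1 to compound 2 (within the scatter). That step touches the same aromatic ring of the benzylamide that is altered in the new compound, and it moved nothing.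

Compound 4 `O=C(O)C[C@H](O)C[C@H](O)CCn1c(-c2ccc(F)cc2)nc(C(=O)NCc2ccc(F)c(F)c2)c1C1CC1` carries the change (3,4-difluorophenyl in place of 4-methoxyphenyl on a saturated chain carbon bound to an amide-type nitrogen). Within the data shown here, the one measured step on this ring, the loss of a fluoro going from compound 1 to compound 2, left the number unchanged, but no measured step covers the removal of the methoxy group or the arrival of two fluorines, so the guidance is thin. The expectation is therefore a step of about a 1.5-fold higher number from compound 2 to compound 4 (0.18 log units; within the scatter), within the scatter, in no clear direction. For compound 4 the estimated value in this assay is 0.3 nM, with a range from 0.1 nM to 0.9 nM.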

Compound 4, half-maximal inhibitory concentration: 0.5 nM
Compound 4: middle estimate off by 1.7-fold (0.22 log units), on the low side; the measured number falls inside the stated range.
By their numbers in this assay, from the lowest: compounds 1, 2, 3 and 4 (each within the scatter of the next, the first and the last beyond it).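

In this assay, among these compounds, the 3,4-difluorophenyl group in place of 4-methoxyphenyl gives a 2.5-fold higher number from compound 2 to compound 4 (0.40 log units; beyond the scatter) and is the first change on this ring to go beyond the scatter, though only modestly. Fluoro in place of methoxy alone gives a 2.5-fold higher number from compound 1 to compound 4 (0.40 log units; beyond the scatter) and so a step of the same size, whereas taking the fluoro away in no change at the digits printed from compound 1 to compound 2 (within the scatter) moved nothing, so among these three compounds it is the loss of the methoxy that shifts the number. Nothing available explains this shift.

On these data alone, what remains open is whether the methoxy group is needed as such, or whether an ethoxy group, a hydroxyl or an amine in its place would hold the number as well. As far as these compounds go, it is equally open whether a chlorine or a nitrile there would match compound 4 or the methoxy compounds.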